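From Furan to Pyrazole in a Channel Agonist

The compounds below may be only part of what the source reports. "The series", "measured", "known", "first", "only" and "open" are said of these compounds alone.

For the measured compounds named here, compound 1 `CCN(Cc1ccoc1)C(=O)COc1ccc(C)cc1` is the only compound in this set with a reported number: in an assay on HEK293 cells for agonist activity at transient receptor potential cation channel subfamily M member 8 (Homo sapiens), read by fluorescence and calcium flux, with a stated time of 15 min (a lower number here means that less compound is needed, a higher number that more compound is needed for the effect), compound 1 gives 136 nM. In this assay compound 2 `CCN(Cc1cccs1)C(=O)c1cc2cc(C)ccc2n1C` is reported as "not active" (no number reported), with no number given. Compound 3 `CCN(Cc1cn[nH]c1)C(=O)COc1ccc(C)cc1` differs from compound 1 in one place: 1H-pyrazol-4-yl in place of furan-3-yl on a saturated chain carbon bound to an amide-type nitrogen. Going by the values given here, no step between two measured compounds is available to set the scale, so a small change in this assay is expected, toward a larger value or none beyond the scatter. Compound 3 is expected to give 250 nM, within 80 nM to 800 nM, which corresponds to the expected step of a 1.8-fold higher number from compound 1 to compound 3 (0.26 log units; within the scatter).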

Compound 3, half-maximal effective concentration: "active" (no number reported)
For compound 3 the study gives words and no number; there is nothing to compare the estimate with.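

For the compounds shown here, compound 3 is reported only in words, so no step from compound 1 can be read. The compounds shown leave open how far 1H-pyrazol-4-yl in place of furan-3-yl shifts the number. No evidence shown here bears on this result.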